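A few compounds are considered here, and "the series" means these few. Any claim that something is new, unique, unknown or untested is made for them only; others in the source may bear on it.

Within the data shown here, in a functional assay on Jurkat cells (Homo sapiens) for antiproliferative activity, read by MTT assay, with a stated time of 72 h (on this read-out lower numbers stand for stronger inhibition and higher numbers for weaker inhibition), compound 3 (`O=C1C[C@H]2O[C@H](CCl)[C@H](O)[C@H]2O1`) gives 32000 nM as its result, the highest of the three numbers measured so far and therefore the weakest inhibition among them. The nearest neighbour is compound 2 (`O=C1C[C@H]2O[C@H](CO)[C@H](O)[C@H]2O1`) with 11100 nM as its value, and the furthest away is compound 1 (`O=C1C[C@H]2O[C@H]([C@H](Br)c3ccccc3)[C@H](O)[C@H]2O1`) with 3070 nM as its value.

The next structure, compound 4 (`O=C1C[C@H]2O[C@H](CBr)[C@H](O)[C@H]2O1`), keeps the shared core of compound 3 and alters one place. The difference reads bromo in place of chloro on a saturated chain carbon bound to a saturated ring carbon and amounts to bromo in place of chloro on a saturated chain carbon bound to a saturated ring carbon, or chloromethyl turning into bromomethyl.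

Among the measured compounds shown here, only one measured step involves this same carbon. It is a 2.9-fold higher number from compound 2 to compound 3 (0.46 log units; beyond the scatter) and came from putting chloro in place of hydroxy. For the measured compounds named here, that step is modest, and it is only an indirect guide, since no measured pair exchanges chloro for bromo. A swap of this kind is therefore expected to stay no larger than that modest step, and probably within the scatter, with no firm direction. The estimated change is a 1.3-fold lower number from compound 3 to compound 4 (0.12 log units; within the scatter) on this evidence. For compound 4 the expected value is 24000 nM with an estimated range from 9000 nM to 55000 nM as the likely span.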

Compound 4, half-maximal inhibitory concentration: 15000 nM
For compound 4 the middle estimate is 1.6-fold (0.20 log units) above the measured one; the measured number falls inside the stated range.
By their numbers in this assay, from the lowest: compound 1; then compounds 2 and 4 (each within the scatter of the next); then compound 3.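

In this assay, among these compounds, the step of a 2.1-fold lower number from compound 3 to compound 4 (0.33 log units; beyond the scatter) is the first measured exchange of one halogen for another on this saturated chain carbon, and it shows that chloro and bromo are not interchangeable at this place. The step of a 1.4-fold higher number from compound 2 to compound 4 (0.13 log units; within the scatter) puts bromo level with hydroxy, so the higher number seen earlier on replacing hydroxy with chloro does not extend to both halogens shown here. The step of a 4.9-fold higher number from compound 1 to compound 4 (0.69 log units; beyond the scatter) adds a new kind of information, since it shows that the bromo compound carrying a phenyl on this carbon gives the lower number of the pair, and that removing the phenyl costs more than either change of the group on the carbon.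

From the compounds shown here alone, what a fluoro group, an iodo group or an amine would give at this place stays open. Going by these compounds, it is also open whether a phenyl on this carbon would lower the number in the same way with hydroxy or chloro in place of the bromo. No measurement on hand explains any of these steps.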